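Cytotoxicity of Three Measured Compounds and One Still Untested

The source may report more compounds than this note shows. Statements on the series, on what has been measured and on what is new or still open speak of the compounds shown alone.

Compound 1 `COc1ccc(NC(=O)Nc2cc(C)nc3ccccc23)cc1OC`: > 25000 nM
Compound 2 `COc1ccc(NC(=O)Nc2cc(C)nc3ccccc23)cc1Cl`: 26000 nM
Compound 3 `Cc1cc(NC(=O)Nc2ccc(Cl)cc2)c2ccccc2n1`: > 25000 nM

In an ADME assay on HEK293 cells (Homo sapiens) for cytotoxicity, with a stated time of 72 h (on this read-out higher numbers stand for an effect only at larger amounts of compound and lower numbers for an effect already at smaller amounts), compound 2 gives 26000 nM. For compound 1 the result is only a limit, > 25000 nM. For compound 3 the result is likewise only a limit, > 25000 nM. Compound 1 and compound 2 differ by methoxy in place of chloro on an aromatic carbon; the resulting step is a step that the limit leaves unreadable from compound 2 to compound 1. The difference between the core of compound 3 and that of compound 2 is not broken down here.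

Compound 4 `COc1ccc(NC(=O)Nc2cc(C)nc3ccccc23)cc1` is still unmeasured. It is reached from compound 3 by methoxy in place of chloro on an aromatic carbon, the same kind of change as that from compound 2 to compound 1, though not the same: there the place is ortho to a methoxy group and meta to a large group, here it is para to a large group.

In this assay the step from compound 3 to compound 4 is expected to be a step that the limit leaves unreadable from compound 3 to compound 4, resting on (the limit of > 25000 nM in this assay, at which 2 of the 3 values shown sit). Compound 4 is therefore estimated at 30000 nM, between 15000 nM and 80000 nM.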

Compound 4, half-maximal effective concentration: > 25000 nM
Compound 4 was reported as a limit; the forecaster's own chance of this, stated with the estimate: 70%; the middle value lies beyond the limit too.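

In this assay compound 4 gives > 25000 nM, which is a limit. No step linking compound 4 to compound 1, compound 2 or compound 3 can be read, because the results stop at a limit: the limit of > 25000 nM in this assay, at which 3 of the 4 values shown sit.

The compounds shown leave open whether replacing chloro with methoxy or hydrogen on the aromatic carbon changes cytotoxicity at all.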